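Swapping the Isobutylamino Group of Compound 2

A few compounds are considered here, and "the series" means these few. Any claim that something is new, unique, unknown or untested is made for them only; others in the source may bear on it.

Among the compounds with values here, in a physicochemical assay for lipophilicity (a lower number here means a more polar compound, a higher number a more lipophilic compound), compound 1 (`CCNC(=O)/C=C(C)/C=C/CC(C)CCCC(C)C`) gives 5.24, and compound 2 (`CC(/C=C/CC(C)CCCC(C)C)=C\C(=O)NCC(C)C`) gives 6.19, the higher of the two numbers so far. The next structure, compound 3 (`CC(/C=C/CC(C)CCCC(C)C)=C\C(=O)CC(C)C`), differs from compound 2 by a single swap: isobutyl in place of isobutylamino on a carbonyl carbon. Isobutylcarbamoyl thus becomes isobutylcarbonyl, with isobutyl in place of isobutylamino on a carbonyl carbon. Within the data shown here, only one measured step is available as a guide, a number 0.95 log units higher from compound 1 to compound 2 (beyond the scatter). That step put isopropyl in place of methyl on a saturated chain carbon bound to an amide-type nitrogen, which is a different change, so it offers only a rough sense of scale. No measurement tests the present swap directly. A modest rise of similar size is expected, and the estimated step is a number 0.71 log units higher from compound 2 to compound 3 (beyond the scatter). For compound 3, the expected value is 6.9, within an estimated range of 6.3 to 7.5.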

Compound 3, partition coefficient: 7.22
The estimate for compound 3 lay 0.32 log units below the measured number; measured number inside the range.
By their numbers in this assay, from the lowest: compound 1; then compound 2; then compound 3.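

This is the first change shown on the carbonyl carbon itself, and in this assay it gives a number 1.03 log units higher from compound 2 to compound 3 (beyond the scatter). The four carbons of the isobutyl part stay, so this large step involves the loss of the nitrogen and its hydrogen-bond donor with no carbon added, whereas the earlier step from compound 1 to compound 2 added carbon to the chain. Taken together, the chain change and this swap amount to a number 1.98 log units higher from compound 1 to compound 3 (beyond the scatter), with isobutyl in place of ethylamino.

Nothing available explains the size of the step from compound 2 to compound 3. The compounds shown leave open whether the nitrogen itself matters or only its hydrogen, and how an isobutoxy group or a longer chain on this carbonyl carbon would read in this assay.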